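Pyrazolyl chalcones: trimethoxy to dimethoxy on the aryl ring

A few compounds are considered here, and "the series" means these few. Any claim that something is new, unique, unknown or untested is made for them only; others in the source may bear on it.

Three compounds of the series have been run in a functional assay on PC-3 cells (Homo sapiens) for cytotoxicity, read by sulforhodamine B assay, with a stated time of 48 h, tested at 100 uM; on this read-out higher numbers stand for a weaker effect at the one concentration tested and lower numbers for a stronger effect. Compound 1 `COc1cc(-c2cc(/C=C/C(=O)c3ccc(N)cc3)[nH]n2)cc(OC)c1OC` gives -39%, and compound 2 `COc1ccc(-c2cc(/C=C/C(=O)c3ccc(N)cc3)[nH]n2)cc1OC` gives -48%. The change from compound 1 to compound 2, (hydrogen in place of methoxy on an aromatic carbon), gave a number 9 percentage points lower from compound 1 to compound 2 (within the scatter). Compound 3 `COc1cc(C(=O)/C=C/c2cc(-c3cc(OC)c(OC)c(OC)c3)n[nH]2)cc(OC)c1OC` gives -94%, the lowest of the three; its gaps to compound 2 and to compound 1 lie beyond the scatter. The difference between the core of compound 3 and that of compound 1 is not broken down here.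

Compound 4 `COc1ccc(-c2cc(/C=C/C(=O)c3cc(OC)c(OC)c(OC)c3)[nH]n2)cc1OC` is the unmeasured member. Its change from compound 3 is hydrogen in place of methoxy on an aromatic carbon, the same change as that from compound 1 to compound 2, in the same place. Because that earlier change gave a number 9 percentage points lower from compound 1 to compound 2 (within the scatter), a step of similar size is expected here, so a number 6 percentage points higher from compound 3 to compound 4 (within the scatter) is estimated. Compound 4 is expected to give about -88% in this assay, between -100% and -65%.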

Compound 4, a percentage reported as activity, at one concentration (the size of the read-out at that concentration, not a potency): -74%
Compound 4: middle estimate off by 14 percentage points, on the low side; the measured number falls inside the stated range.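

Hydrogen in place of methoxy on an aromatic carbon gives a number 20 percentage points higher from compound 3 to compound 4 (beyond the scatter) in this assay, so on this core the loss of the methoxy group comes with a real shift in the read-out. This does not show why the two cores respond differently, and two steps give no rule for the series, only a warning against carrying a step read on one of these cores over to the other. The step does not transfer between the two cores: the same change on two cores in this assay, a number 9 percentage points lower (within the scatter) from compound 1 to compound 2 and a number 20 percentage points higher (beyond the scatter) from compound 3 to compound 4, 29 percentage points apart, beyond the scatter of two such steps

The compounds shown leave open how a hydroxy group, a fluorine atom or a longer alkoxy chain would read in place of this methoxy group. They also leave open what the same change does on any further core.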